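Quinoline ether amides and liver-cell toxicity: a hydrazide variant

The source may report more compounds than this note shows. Statements on the series, on what has been measured and on what is new or still open speak of the compounds shown alone.

Compound 1, `CSc1ccc2nc(C)cc(OCC(=O)Nc3cc(C)cc(C)c3)c2c1`, in a toxicity assay on HepG2 cells (Homo sapiens) for inhibition, read by CellTiter-Glo, with a stated time of 48 h (on this read-out lower numbers stand for stronger inhibition and higher numbers for weaker inhibition), gives a value at the assay limit, > 100000 nM.
Compound 2, `COc1cc2nc(C)cc(OCC(=O)Nc3cc(C)cc(C)c3)c2cc1OC`, in this assay gives 10000 nM.
Compound 3, `COc1ccc2nc(C)cc(OCC(=O)Nc3ccccc3)c2c1`, in this assay gives 39800 nM.

Of the two numbers measured, compound 3 holds the higher one; its nearest neighbour is compound 2, whose number is lower by a gap that lies beyond the scatter. The value for compound 1 is only a limit of the assay, (the limit of > 100000 nM in this assay, at which 1 of the 3 values shown sits), and says no more than that.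

Compound 4, `COc1ccc2nc(C)cc(OCC(=O)NNC(=O)c3ccncc3)c2c1`, has not yet been measured in this assay. It differs from compound 3 in one place: ((pyridin-4-yl)carbonyl)amino in place of phenyl on an amide-type nitrogen. Going by the values given here, with no measured pair isolating this change, the direction can only be reasoned from the weak toxicity seen across compound 2 and compound 3, both far from potent, and from compound 1 sitting at the limit.

The expectation is a small step from compound 3 to compound 4 in this assay, toward a higher number, of size a 1.6-fold higher number from compound 3 to compound 4 (0.20 log units; within the scatter), possibly no more than the scatter. For compound 4 the estimated value in this assay is 63000 nM, with a range from 16000 nM to 200000 nM, and a real chance that only a limit is reported.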

Compound 4, half-maximal inhibitory concentration: > 100000 nM
Compound 4: no number, only a limit (the forecaster's own chance of this, stated with the estimate: 45%); at least 1.5-fold (0.20 log units) between middle value and limit.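

Putting ((pyridin-4-yl)carbonyl)amino in place of phenyl on an amide-type nitrogen gives the only readable step among the compounds shown, and it shows that this position can affect the read-out: in this assay the change gives an at least 2.5-fold higher number from compound 3 to compound 4 (0.40 log units; beyond the scatter), toward weaker inhibition and beyond the scatter. Compound 4 gives > 100000 nM, which is a limit of the assay and not a number. The step is therefore only a lower bound, and its full size cannot be told: the limit of > 100000 nM in this assay, at which 2 of the 4 values shown sit.

The compounds shown leave open whether the shift comes from the added carbonyl and amino link or from the pyridin-4-yl ring, a question that a benzoylamino group, with phenyl in place of that ring on the same link, would help to separate. They also leave open whether a pyridin-4-yl ring placed directly on the amide-type nitrogen, without the carbonyl and amino link, would move the number in the same direction in this assay.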